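This account rests on a few compounds, and the source may have more. Where it says the series, first, only, none or still open, it means among the compounds named here.

Of the compounds shown here, three sharing one core have been tested in an assay on CHO cells for displacement of a labelled ligand from Melanocortin receptor 4 (Homo sapiens); on this read-out higher numbers stand for weaker inhibition and lower numbers for stronger inhibition. Compound 1 `CC[C@H](NC(C)=O)c1cc(Cl)ccc1C1CCN(C(=O)[C@H]2CN(C(C)(C)C)C[C@@H]2c2ccc(F)cc2F)CC1` gives 640 nM. Compound 2 `CC[C@H](NC(C)=O)c1cc(Cl)ccc1C1CCN(C(=O)[C@H]2CN(C(C)(C)C)C[C@@H]2c2ccc(Cl)cc2Cl)CC1` gives 3.3 nM. Compound 3 `CC[C@H](NC(C)=O)c1cc(Cl)ccc1C1CCN(C(=O)[C@H]2CN(C(C)(C)C)C[C@@H]2c2ccc(F)cc2Cl)CC1` gives 82.2 nM, the second highest of the three numbers, nearer to compound 1 than to compound 2. The measured steps are a 190-fold lower number from compound 1 to compound 2 (2.29 log units; beyond the scatter), a 7.8-fold lower number from compound 1 to compound 3 (0.89 log units; beyond the scatter) and a 25-fold higher number from compound 2 to compound 3 (1.40 log units; beyond the scatter). Compound 4 `CC[C@H](NC(C)=O)c1cc(Cl)ccc1C1CCN(C(=O)[C@H]2CN(C(C)(C)C)C[C@@H]2c2ccc(Cl)cc2F)CC1` has not yet been measured; it differs from compound 3 by 4-chloro-2-fluorophenyl in place of 2-chloro-4-fluorophenyl on a saturated ring carbon, the same atoms joined differently. The step from compound 2 to compound 3 was far larger than the step from compound 1 to compound 3, so the swap in compound 4 bears on the larger of the two. A lower number is therefore expected for compound 4, a 3.2-fold lower number from compound 3 to compound 4 (0.50 log units; beyond the scatter). Compound 4 is estimated at 26 nM, within 8 nM to 80 nM.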

Compound 4, half-maximal inhibitory concentration: 13.2 nM
Estimate against measurement, compound 4: 2.0-fold (0.29 log units) above; measured number inside the range.
By their numbers in this assay, from the lowest: compound 2; then compound 4; then compound 3; then compound 1.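

Which halogen sits where matters even with the same atoms: the move gives a 6.2-fold lower number from compound 3 to compound 4 (0.79 log units; beyond the scatter). Compound 4 shows that the chlorine of 4-chloro-2-fluorophenyl carries most of the gain, with a 48-fold lower number from compound 1 to compound 4 (1.69 log units; beyond the scatter), while changing the other chlorine of the 2,4-dichlorophenyl group to fluoro gives only a 4.0-fold higher number from compound 2 to compound 4 (0.60 log units; beyond the scatter). The larger change keeps its size whichever halogen accompanies it: the same change on two cores in this assay, a 25-fold higher number (1.40 log units; beyond the scatter) from compound 2 to compound 3 and a 48-fold higher number (1.69 log units; beyond the scatter) from compound 4 to compound 1, 1.9-fold (0.29 log units) apart, within the scatter of two such steps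

From the compounds shown here alone, whether methyl, methoxy or trifluoromethyl could stand in for either halogen remains open. So does how a phenyl carrying a single chlorine would compare.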